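This account rests on a few compounds, and the source may have more. Where it says the series, first, only, none or still open, it means among the compounds named here.

Two compounds of the shared core have numbers in a functional assay on HeLa cells (Homo sapiens) for inhibition, read by CCK-8 assay, with a stated time of 72 h, tested at 8 uM; a lower number here means less inhibition of growth, a higher number more inhibition of growth at the concentration tested. Compound 1 `Nc1ccccc1NC(=O)/C=C/c1ccc(CSc2ccc(F)cc2)cc1` gives 10.4%, the lowest of the two. Compound 2 `Nc1ccccc1NC(=O)c1ccc(CSc2ccc(Cl)cc2)cc1` gives 51.4%, a number beyond the scatter above compound 1; the two differ in more than one place, so only the two values can be compared. Compound 3 `Nc1ccccc1NC(=O)/C=C/c1ccc(CSCCc2ccccc2)cc1` carries phenethyl in place of 4-fluorophenyl on a sulfur. Among the compounds with values here, no measured pair covers this change. The step of a number 3.6 percentage points higher from compound 1 to compound 3 (within the scatter) is expected to stay within the scatter. Compound 3 is estimated at 14%, likely between 0% and 35%.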

Compound 3, percent growth inhibition at one concentration: 3.57%
For compound 3 the middle estimate is 10.4 percentage points above the measured one; the measured number falls inside the stated range.
By their numbers in this assay, from the lowest: compounds 3 and 1 (each within the scatter of the next); then compound 2.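

In this assay, phenethyl in place of 4-fluorophenyl on a sulfur gives a number 6.8 percentage points lower from compound 1 to compound 3 (within the scatter). Within the data shown here, this is the first step read at this position: on this core, the number stays within the scatter when the aromatic ring is moved from the sulfur onto a chain. Nothing available explains this result. As far as these compounds go, whether an amine or a carboxylic acid at the end of this chain, or a longer chain, would move the number beyond the scatter remains open. Also open, from the compounds shown here alone, is how the same change would read on the core of compound 2.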